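Replacing the Amide Aryl Group with a Phenylpropyl Chain

The source may report more compounds than this note shows. Statements on the series, on what has been measured and on what is new or still open speak of the compounds shown alone.

For the measured compounds named here, the series rests on a shared core carrying an amide, and the two measured members differ only in the group attached to the carbonyl carbon. Compound 1 `COc1ccccc1N1CCN(CCCCNC(=O)c2ccc(I)cc2)CC1` bears a 4-iodophenyl group there, and in an assay on frontal cortex for binding affinity to Adrenergic receptor alpha-1 (Rattus norvegicus), read by radioligand binding (a lower number here means a stronger inhibitor, a higher number a weaker inhibitor), compound 1 gives 15 nM. Compound 2 `COc1ccccc1N1CCN(CCCCNC(=O)c2ccc(O)cc2)CC1` carries a 4-hydroxyphenyl group instead, and in this assay compound 2 gives 17 nM. The step of a 1.1-fold higher number from compound 1 to compound 2 (0.05 log units; within the scatter) shows that exchanging iodo for hydroxy on that aromatic carbon leaves the number essentially unchanged. Compound 2 thus has the highest of the two numbers, but its gap to compound 1 lies within the scatter, so no order between them can be claimed.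

Compound 3 `COc1ccccc1N1CCN(CCCCNC(=O)CCCc2ccccc2)CC1` goes further: the change is 3-phenylpropyl in place of 4-hydroxyphenyl on a carbonyl carbon. Going by the values given here, no measured step in this set touches the aryl group itself; the only step at hand concerns a substituent on it and was within the scatter, so it offers little guidance. For compound 3 a modest weakening is expected, with the step of a 2.1-fold higher number from compound 2 to compound 3 (0.31 log units; beyond the scatter) judged plausible but uncertain. Compound 3 is therefore estimated at 35 nM, within a range of 8 nM to 150 nM.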

Compound 3, inhibition constant: 84 nM
Beside the measured number, compound 3's estimate is 2.4-fold (0.38 log units) below it, within the range that was stated.
By their numbers in this assay, from the lowest: compounds 1 and 2 (each within the scatter of the next); then compound 3.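

Exchanging the whole aryl group on the carbonyl carbon for 3-phenylpropyl produces what the substituent exchange did not, a step beyond the scatter in this assay: a 4.9-fold higher number from compound 2 to compound 3 (0.69 log units; beyond the scatter) and a 5.6-fold higher number from compound 1 to compound 3 (0.75 log units; beyond the scatter) are both steps toward a weaker inhibitor. Since compound 1 and compound 2 lie within the scatter of each other, the weakening appears whether the departing ring carried iodo or hydroxy, and this position therefore responds to the group as a whole more clearly than to that single substituent. The change also alters several features at once, including the heavy-atom count and the hydroxy group's donor and acceptor, and no accompanying data explain the weakening.

As far as these compounds go, it remains open whether the chain's presence or its length governs the step, which unsubstituted phenyl, 2-phenylethyl and 4-phenylbutyl on the same carbonyl carbon could help to separate. Also open, from the compounds shown here alone, is whether hydroxy or iodo on the ring of the 3-phenylpropyl group would leave the number as little changed as it did on the aryl group of compound 1 and compound 2.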